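This account rests on a few compounds, and the source may have more. Where it says the series, first, only, none or still open, it means among the compounds named here.

Measured so far in an ADME assay on Huh-7 cells (Homo sapiens) for cytotoxicity, read by MTT assay, with a stated time of 4 h, at 37 degrees C (a higher number here means that more compound is tolerated, a lower number that less compound is tolerated), for this series:
- compound 1 `COCCn1c(=O)c(-c2c(Cl)cccc2Cl)cc2c(N)nc(Nc3ccccc3)nc21` at 241000 nM
- compound 2 `CCCOCCNc1nc(Oc2ccccc2)nc2[nH]c(=O)c(-c3ccc(F)cc3)cc12` at 79800 nM
- compound 3 `O=C1Nc2nc(NCc3ccccc3)[nH]c(=O)c2CC1c1c(Cl)cccc1Cl` at 69000 nM

Compound 1 stands highest of these three, and its gaps to compound 2 and to compound 3 both lie beyond the usual scatter. Within the data shown here, those two differ from compound 1 in more than one place, so the set holds no measured single-change step.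

Compound 4 `CCCn1c(=O)c(-c2c(Cl)cccc2Cl)cc2c(N)nc(Nc3ccccc3)nc21` is still unmeasured. Its change from compound 1 is methyl in place of methoxy on a saturated chain carbon, two bonds along the chain from an aromatic nitrogen and reads in words as methyl in place of methoxy on a saturated chain carbon, two bonds along the chain from an aromatic nitrogen.

Without a measured precedent, only a rough expectation is possible. A small downward step in this assay is expected, possibly none beyond the scatter, with compound 2 at 79800 nM and compound 3 at 69000 nM as the only lower reference points. The expected move is a 1.6-fold lower number from compound 1 to compound 4 (0.21 log units; within the scatter) on this estimate. Compound 4 is estimated at 150000 nM with an expected range from 60000 nM to 350000 nM as its likely span.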

Compound 4, half-maximal cytotoxic concentration: 181000 nM
The estimate for compound 4 lay 1.2-fold (0.08 log units) below the measured number; the measured number falls inside the stated range.
By their numbers in this assay, from the lowest: compounds 3 and 2 (each within the scatter of the next); then compounds 4 and 1 (each within the scatter of the next).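

Working notes: this is the first single-change step in the series. In this assay, 2-methoxyethyl to propyl on the aromatic nitrogen of the shared core gives a 1.3-fold lower number from compound 1 to compound 4 (0.12 log units; within the scatter), a step within the scatter. On this core, then, the methoxy group and its hydrogen-bond acceptor can give way to methyl with no measurable shift in the tolerated concentration, and no measurement on hand offers an explanation for the size of this step.

The compounds shown hold only these two groups at this position, so it remains open whether an amine, a carboxylic acid or a longer chain there would move the number beyond the scatter. From the compounds shown here alone, whether the same change would behave alike on the cores of compound 2 or compound 3 also remains open.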